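From methoxy to methoxymethyl on a saturated ring carbon

A few compounds are considered here, and "the series" means these few. Any claim that something is new, unique, unknown or untested is made for them only; others in the source may bear on it.

Compound 1 (`C[C@]1(C(=O)O)CC[C@H](C(=O)N2CC[C@](c3ccc(C(F)(C(F)(F)F)C(F)(F)F)cc3)(S(=O)(=O)c3ccc(F)cc3)C2)CC1`), compound 2 (`CCC[C@]1(C(=O)N2CC[C@](c3ccc(C(F)(C(F)(F)F)C(F)(F)F)cc3)(S(=O)(=O)c3ccc(F)cc3)C2)CC[C@H](C(=O)O)CC1`) and compound 3 (`CO[C@]1(C(=O)N2CC[C@](c3ccc(C(F)(C(F)(F)F)C(F)(F)F)cc3)(S(=O)(=O)c3ccc(F)cc3)C2)CC[C@H](C(=O)O)CC1`) share one core and each carry a carboxy group on a six-membered non-aromatic ring of carbon only. In an ADME assay on microsomes from liver (Mus musculus) for metabolic stability, with a stated time of 10 min (a higher number here means that more of the compound is left, a lower number that less of the compound is left), compound 1 gives 93%. In this assay compound 3 gives 95%, which lies within the scatter of compound 1, so the two stand level. For compound 2 the entry reads "not determined" (no result reported), so it offers no number to compare.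

Compound 4 (`COC[C@]1(C(=O)N2CC[C@](c3ccc(C(F)(C(F)(F)F)C(F)(F)F)cc3)(S(=O)(=O)c3ccc(F)cc3)C2)CC[C@H](C(=O)O)CC1`) has not been measured yet. Its structure differs from compound 3 as follows: methoxymethyl in place of methoxy on a saturated ring carbon. In words, this is methoxymethyl in place of methoxy on a saturated ring carbon.

For the measured compounds named here, only one measured step bears on this change: a number 2 percentage points higher from compound 1 to compound 3 (within the scatter). That step also exchanged a group on this ring, and it stayed small. Going by the values given here, a single step is thin evidence, and no measured compound carries methoxymethyl, so the range must stay wide. The estimated change, a number 3 percentage points lower from compound 3 to compound 4 (within the scatter), is expected to stay inside the scatter, with no firm direction.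

For compound 4 the expected value is 92%, with an estimated range from 80% to 99%.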

Compound 4, percent of the compound remaining: 88%
The estimate for compound 4 lay 4 percentage points above the measured number; measured number inside the range.
By their numbers in this assay, from the lowest: compounds 4, 1 and 3 (each within the scatter of the next).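

Compound 4 is the first compound shown with an oxygen set one carbon further out from this saturated ring carbon, and the change leaves the read-out in the scatter: in this assay the step is a number 7 percentage points lower from compound 3 to compound 4 (within the scatter). Set against the compound with the methyl group on the ring, the comparison gives the same reading, a number 5 percentage points lower from compound 1 to compound 4 (within the scatter), so compounds 1, 3 and 4 stand level and all three ring variants with a measured number are alike in this assay, which extends what the step from compound 1 to compound 3 suggested to a third group. No accompanying measurement bears on what lies behind these numbers, so they describe the outcome and give no explanation of it.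

As far as these compounds go, how an amine or a longer ether chain on this ring carbon would fare in this assay stays open, and so does whether such a group would move the number beyond the scatter. Compound 2 offers no number, so a plain carbon chain at this place also remains unread.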